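The source may hold more compounds than are shown below. What is called first, only, known or untested is meant among the compounds shown, and "the series" means these compounds.

The measured compounds and their values in an assay on CHO cells for displacement of a labelled ligand from adenosine receptor A1 (Homo sapiens), read by scintillation counting, tested at 10 uM; on this read-out higher numbers stand for more inhibition at the one concentration tested (going by the name of the read-out) and lower numbers for less inhibition:
compound 1, `CC(C)(C)Cc1csc(N)c1C(=O)c1ccc(Cl)cc1`: 1%
compound 2, `CC(C)(C)Cc1c(/C=C/c2ccc(Cl)cc2)sc(N)c1C(=O)c1ccc(Cl)cc1`: 1%

Compound 3, `CC(C)(C)Cc1c(-c2ccc(Cl)c(Cl)c2)sc(N)c1C(=O)c1ccc(Cl)cc1`, has not yet been tested in this assay.

On the numbers shown, compound 2 stands level with compound 1 in this assay at the digits given, and compound 1 is its only neighbour for comparison. Going by the values given here, both values sit at the very bottom of the scale, meaning that at the single concentration tested neither compound displaces much of the labelled ligand. Among the compounds with values here, the one measured step, no change at the digits printed from compound 1 to compound 2 (within the scatter), shows that the substitution on the shared core left the read-out where it was. Compound 3 differs from compound 2 by 3,4-dichlorophenyl in place of 2-(4-chlorophenyl)ethenyl on an aromatic carbon. Within the data shown here, the only step that bears on this is the one from compound 1 to compound 2, which was flat; it concerns the same aromatic carbon but a different group, so its guidance is limited. The expected step is therefore a number 2 percentage points higher from compound 2 to compound 3 (within the scatter), no movement beyond the scatter. Compound 3 is estimated to give 3% in this assay, within the range -8% to 18%.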

Compound 3, a percentage reported as inhibition, at one concentration (the size of the read-out at that concentration, not a potency): 1%
The estimate for compound 3 lay 2 percentage points above the measured number; the range from low to high includes it.
By their numbers in this assay, from the lowest: compounds 1, 2 and 3 (each within the scatter of the next).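

In this assay, placing 3,4-dichlorophenyl on the aromatic carbon next to the ring sulfur gives no change at the digits printed from compound 2 to compound 3 (within the scatter) when it replaces 2-(4-chlorophenyl)ethenyl, and no change at the digits printed from compound 1 to compound 3 (within the scatter) when it replaces hydrogen. This position has now carried two different chlorinated aromatic groups, one joined through a double bond and one joined directly to the ring, and neither moves the read-out away from the bottom of the scale, so in these compounds the linkage makes no visible difference. Nothing shown here explains why the read-out stays so low.

All three compounds sit at the same low level, so the set cannot show whether this position can influence the read-out at all, or whether a different kind of group, such as an aminomethyl group or a carboxylic acid, would give a different number there. It also leaves open what would happen if the neopentyl group or the (4-chlorophenyl)carbonyl group were replaced, since both stay the same throughout and any change in this assay might depend on those places instead.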